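Adding a Hydroxy Group to the Acid Chain of Compound 1

This account rests on a few compounds, and the source may have more. Where it says the series, first, only, none or still open, it means among the compounds named here.

Measured so far:
compound 1 `O=C(O)CCCCCCc1sccc1CCCc1ccccc1` gives 1000 nM;
compound 2 `O=C(O)CCCCc1sccc1CCCc1ccccc1` gives 3500 nM;
compound 3 `O=C(O)CCCCCCc1sc(-c2ccccc2)cc1CCCc1ccccc1` gives 1000 nM.

All three numbers come from an assay on spleen (Cavia porcellus) with leukotriene B4 receptor 1 (Homo sapiens) as the target; on this read-out lower numbers stand for stronger inhibition and higher numbers for weaker inhibition. Compound 1 stands level with compound 3 at the digits shown, and the two of them have the lowest numbers of the three; compound 2 stands furthest away. The shortening of the acid chain gave a 3.5-fold higher number from compound 1 to compound 2 (0.54 log units; beyond the scatter), while a phenyl in place of hydrogen on the core gave no change at the digits printed from compound 1 to compound 3 (within the scatter).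

Compound 4 `O=C(O)CCCCCC(O)c1sccc1CCCc1ccccc1` differs from compound 1 by hydroxy in place of hydrogen on a saturated chain carbon bound to an aromatic carbon and a saturated chain carbon. Neither measured step touches this position: one changes the length of the acid chain, the other adds a ring to the core. Among the measured compounds shown here, neither therefore bears directly on a hydroxy on the chain carbon next to the core, and there is no measured step of this kind to lean on. Without such a step, the expectation in this assay is a change of no more than the usual scatter, so the expected step is no change at the digits printed from compound 1 to compound 4 (within the scatter). Compound 4 is thus estimated at 1000 nM, with a range from 300 nM to 3500 nM.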

Compound 4, half-maximal inhibitory concentration: 6000 nM
For compound 4 the middle estimate is 6.0-fold (0.78 log units) below the measured one; measured number outside the range, above it.
By their numbers in this assay, from the lowest: compounds 1 and 3 (each within the scatter of the next); then compounds 2 and 4 (each within the scatter of the next).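

In this assay, hydroxy in place of hydrogen on a saturated chain carbon bound to an aromatic carbon and a saturated chain carbon gives a 6.0-fold higher number from compound 1 to compound 4 (0.78 log units; beyond the scatter) and so shows that this carbon is sensitive to substitution, even though the change adds only one heavy atom. The earlier phenyl step, no change at the digits printed from compound 1 to compound 3 (within the scatter), showed no such sensitivity at its place on the core, so compound 1 does not tolerate change equally at every position tried. Nothing available explains why the hydroxy raises the number.

A single group at this carbon cannot show whether a methyl, a fluorine or a carbonyl there would raise the number too. From the compounds shown here alone, it also remains open whether the hydroxy would have a similar effect with the shorter acid chain of compound 2 or the phenyl of compound 3.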